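This account rests on a few compounds, and the source may have more. Where it says the series, first, only, none or still open, it means among the compounds named here.

Measured so far in a functional assay on HCC1937 cells (Homo sapiens) for antiproliferative activity, read by CCK-8 assay, with a stated time of 72 h; a higher number here means a weaker inhibitor, a lower number a stronger inhibitor:
compound 1 `O=C(Nc1cccc(-c2oc3cc(-c4ccc(F)cc4)ccc3c(=O)c2O)c1)c1ccc(Cl)cc1` — 4030 nM
compound 2 `O=C(Nc1cccc(-c2oc3cc(-c4ccc(F)cc4)ccc3c(=O)c2O)c1)c1ccc(C(F)(F)F)cc1` — 7350 nM
compound 3 `O=C(Nc1cccc(-c2oc3cc(-c4ccc(F)cc4)ccc3c(=O)c2O)c1)c1cc(F)cc(F)c1` — 2070 nM

Compound 3 holds the lowest of the three numbers in this assay; only its gap to compound 2 lies beyond the scatter, a 3.6-fold lower number from compound 2 to compound 3 (0.55 log units; beyond the scatter), while a 1.9-fold lower number from compound 1 to compound 3 (0.29 log units; within the scatter) is within it. Compound 4 `N#Cc1ccc(C(=O)Nc2cccc(-c3oc4cc(-c5ccc(F)cc5)ccc4c(=O)c3O)c2)cc1` differs from compound 3 by 4-cyanophenyl in place of 3,5-difluorophenyl on a carbonyl carbon. Within the data shown here, the steps that bear on this sit at the same carbonyl carbon, a 1.9-fold lower number from compound 1 to compound 3 (0.29 log units; within the scatter) and a 3.6-fold lower number from compound 2 to compound 3 (0.55 log units; beyond the scatter), together with a 1.8-fold higher number from compound 1 to compound 2 (0.26 log units; within the scatter). Both measured aryl groups other than 3,5-difluorophenyl gave higher numbers, so compound 4 is expected to sit somewhat above compound 3, by a 1.7-fold higher number from compound 3 to compound 4 (0.23 log units; within the scatter), a step likely near the edge of the scatter. Compound 4 is estimated at 3500 nM, with a range from 1500 nM to 8500 nM.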

Compound 4, half-maximal inhibitory concentration: 2990 nM
Compound 4: the middle estimate sits 1.2-fold (0.07 log units) above what was measured; the measured number falls inside the stated range.
By their numbers in this assay, from the lowest: compounds 3, 4, 1 and 2 (each within the scatter of the next, the first and the last beyond it).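

Read in this assay, 4-cyanophenyl on this carbonyl carbon stays within the scatter of both 3,5-difluorophenyl, with a 1.4-fold higher number from compound 3 to compound 4 (0.16 log units; within the scatter), and 4-chlorophenyl, with a 1.3-fold lower number from compound 1 to compound 4 (0.13 log units; within the scatter). Cyano in place of trifluoromethyl on the aromatic carbon gives the one step here that clears the scatter, a 2.5-fold lower number from compound 2 to compound 4 (0.39 log units; beyond the scatter), so that ring tolerates a nitrile at least as well as trifluoromethyl. No measurement shown accounts for these differences. Still open, on these data alone, is how an amine or a carboxylic acid on this aryl ring would read, and whether a longer chain could replace the ring on this carbonyl carbon.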